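A few compounds are considered here, and "the series" means these few. Any claim that something is new, unique, unknown or untested is made for them only; others in the source may bear on it.

Compound 1, `Cc1noc(C)c1-c1ccc2c(c1)C(c1ccccc1)NC(=O)N2C`, gives 6.8% in an ADME assay on MCF-10A cells (Homo sapiens) for inhibition, read by MTT assay, with a stated time of 48 h, tested at 2 uM; on this read-out lower numbers stand for less inhibition and higher numbers for more inhibition at the one concentration tested (going by the name of the read-out).
Compound 2, `Cc1noc(C)c1-c1ccc2c(c1)C(c1ccccc1)N(Cc1nnc(-c3ccccc3)o1)C(=O)N2C`, gives 12.4% in this assay.
Compound 3, `Cc1noc(C)c1-c1ccc2c(c1)C(c1ccccc1)N(Cc1nnc(-c3ccccc3)s1)C(=O)N2C`, gives 3.3% in this assay.

Compound 3 stands lowest of the three numbers, yet neither neighbour is separated from it by more than the usual scatter: the step of a number 3.5 percentage points lower from compound 1 to compound 3 (within the scatter) and the step of a number 9.1 percentage points lower from compound 2 to compound 3 (within the scatter) are both within it. The step of a number 5.6 percentage points higher from compound 1 to compound 2 (within the scatter) is likewise within the scatter, so across these three compounds this assay shows no movement that can be trusted.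

Compound 4, `Cc1noc(C)c1-c1ccc2c(c1)C(c1ccccc1)N(Cc1csc(-c3ccc(F)cc3)n1)C(=O)N2C`, has not yet been measured. It differs from compound 3 in one place: 2-(4-fluorophenyl)-1,3-thiazol-4-yl in place of 5-phenyl-1,3,4-thiadiazol-2-yl on a saturated chain carbon bound to an amide-type nitrogen in a ring. The measured step that bears on this is a number 9.1 percentage points lower from compound 2 to compound 3 (within the scatter), where one five-membered heteroaryl replaced another on the same saturated chain carbon and the number stayed within the scatter. The change to the 2-(4-fluorophenyl)-1,3-thiazol-4-yl group is of the same kind, so no step beyond the scatter is expected in this assay, in either direction. Compound 4 is therefore estimated at 7%, with a range from 0% to 16%. The step this estimate implies, a number 3.7 percentage points higher from compound 3 to compound 4 (within the scatter), is expected to lie within the scatter.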

Compound 4, a percentage reported as inhibition, at one concentration (the size of the read-out at that concentration, not a potency): 6.8%
Estimate against measurement, compound 4: 0.2 percentage points above, and the stated range covers the measured number.
By their numbers in this assay, from the lowest: compounds 3, 1, 4 and 2 (each within the scatter of the next).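

At the saturated chain carbon bound to an amide-type nitrogen in a ring, this assay now covers a third heteroaryl group: the step of a number 3.5 percentage points higher from compound 3 to compound 4 (within the scatter) and the step of a number 5.6 percentage points lower from compound 2 to compound 4 (within the scatter) show that 2-(4-fluorophenyl)-1,3-thiazol-4-yl behaves here like both earlier groups. The flat picture therefore extends beyond the exchange of 1,3,4-oxadiazole for 1,3,4-thiadiazole to a change in the five-membered ring and a fluorine on the phenyl ring together, and the printed values of compound 1 (6.8%), which carries only the hydrogen, and compound 4 (6.8%) are the same. No supporting data accompany this result that could explain it.

The compounds shown leave open whether an amine, a carboxylic acid or a longer chain at this same position would give a number that stands clear of the scatter. Since every number here comes from the single concentration of this assay, they also leave open how these compounds would read at other concentrations.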